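Working notes: from compound 1 to compound 4

The source may report more compounds than this note shows. Statements on the series, on what has been measured and on what is new or still open speak of the compounds shown alone.

Values in a functional assay on KB cells (Homo sapiens) for inhibition, read by sulforhodamine B assay, with a stated time of 72 h (a lower number here means a stronger inhibitor of growth, a higher number a weaker inhibitor of growth), so far:
- compound 1 `NNC(=O)CCc1ccncc1-c1ccc2ccccc2c1` gives > 10000 nM as a limit
- compound 2 `O=C(CCc1ccncc1-c1ccc2ccccc2c1)N1CCOCC1` gives > 10000 nM as a limit
- compound 3 `CCOC(=O)/C=C/c1ccncc1-c1ccc2c(ccn2C)c1` gives 6250 nM as a number

Compound 1 stands at a limit, > 10000 nM, and has no measured number. Among the compounds with values here, the series so far is dominated by the limit of > 10000 nM in this assay, at which 2 of the 3 values shown sit, and compound 2 sits there too. Within the data shown here, the only measured step is a step that the two limits leave unreadable from compound 1 to compound 2 and it gives no size to carry forward.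

The next change leads to compound 4 `NC(=O)/C=C/c1ccncc1-c1ccc2ccccc2c1`. It puts 2-carbamoylethenyl in place of 2-(aminocarbamoyl)ethyl on an aromatic carbon, opposite the ring nitrogen 2-carbamoylethenyl in place of 2-(aminocarbamoyl)ethyl on an aromatic carbon in the core of compound 1.

Among the measured compounds shown here, no measured step covers this change. For the measured compounds named here, compound 3, at 6250 nM in this assay, is the one compound with a number, and it also has a double bond in its chain. Going by the values given here, its core differs from that of compound 1, however, and no step links the two, so it offers only weak support.

Only a small move toward stronger inhibition is therefore expected, with the estimate an at least 1.1-fold lower number from compound 1 to compound 4 (0.04 log units; that floor lies within the scatter) lying within the scatter and possibly hidden by the limit. The expected value for compound 4 is 9000 nM, with an estimated range from 3500 nM to 20000 nM.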

Compound 4, concentration for 50% growth inhibition: > 10000 nM
Compound 4 ended at the assay's limit (the forecaster's own chance of this, stated with the estimate: 60%); middle value at least 1.1-fold (0.04 log units) from the limit.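

In this assay compound 4 gives > 10000 nM, a limit and not a number. No size can be read for the step between compound 1 and compound 4, since both stand at a limit: the limit of > 10000 nM in this assay, at which 3 of the 4 values shown sit.

The compounds shown leave open whether 2-carbamoylethenyl in place of 2-(aminocarbamoyl)ethyl changes growth inhibition at all.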